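A few compounds are considered here, and "the series" means these few. Any claim that something is new, unique, unknown or untested is made for them only; others in the source may bear on it.

Compound 1 `COc1ccc(N2CCN(C(=S)SCc3ccc(C(=O)Nc4ccccc4N)cc3)CC2)cc1`: in a functional assay on HeLa cells (Homo sapiens) for antiproliferative activity, read by CCK-8 assay, with a stated time of 72 h, tested at 8 uM (on this read-out higher numbers stand for a stronger effect at the one concentration tested and lower numbers for a weaker effect), compound 1 gives 52.3%
Compound 2 `CN1CCN(C(=S)SCc2ccc(C(=O)Nc3ccccc3N)cc2)CC1`: in this assay compound 2 gives 75.7%

Compound 2 stands highest of the two numbers in this assay; compound 1 sits below it, the change being a number 23.4 percentage points higher from compound 1 to compound 2 (beyond the scatter). Compound 3 `Nc1ccccc1NC(=O)c1ccc(CSC(=S)N2CCN(c3ccncc3)CC2)cc1` is not yet measured in this assay. It differs from compound 2 by pyridin-4-yl in place of methyl on an amine nitrogen in a ring. Among the compounds with values here, the one step that bears on this is a number 23.4 percentage points higher from compound 1 to compound 2 (beyond the scatter), in which 4-methoxyphenyl on that ring nitrogen gave way to methyl and the number rose. Compound 3 puts a six-membered aromatic ring back in the same place, though a different one, so a step downward is expected, probably smaller than that earlier step: a number 15.7 percentage points lower from compound 2 to compound 3 (beyond the scatter). For compound 3 the estimated value in this assay is 60%, with a range from 42% to 78%.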

Compound 3, a percentage reported as inhibition, at one concentration (the size of the read-out at that concentration, not a potency): 77.4%
Compound 3: the middle estimate sits 17.4 percentage points below what was measured; measured number inside the range.
By their numbers in this assay, from the lowest: compound 1; then compounds 2 and 3 (each within the scatter of the next).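

On the ring nitrogen, pyridin-4-yl in place of methyl leaves the read-out in this assay within the scatter (a number 1.7 percentage points higher from compound 2 to compound 3 (within the scatter)). A six-membered aromatic ring at this position therefore does not by itself go with the lower number: with pyridin-4-yl in place of 4-methoxyphenyl, the series shows (a number 25.1 percentage points higher from compound 1 to compound 3 (beyond the scatter)). No measurement here accounts for the gap between these two aromatic groups.

Open, as far as these compounds go, is whether a plain phenyl on that ring nitrogen would sit with compound 1 or with compounds 2 and 3. Also open, from the compounds shown here alone, is how a longer alkyl chain or a carboxylic acid would read there.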